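Growing the Side Chain of Compound 2

This account rests on a few compounds, and the source may have more. Where it says the series, first, only, none or still open, it means among the compounds named here.

Compound 1, `CCCCc1cn(CCNc2nonc2/C(=N/O)Nc2ccc(F)c(Br)c2)nn1`, gives 830 nM in an assay on isolated protein for inhibition of Indoleamine 2,3-dioxygenase 2 (Homo sapiens); a higher number here means a weaker inhibitor, a lower number a stronger inhibitor.
Compound 2, `CC(C)(O)c1cn(CCNc2nonc2/C(=N/O)Nc2ccc(F)c(Br)c2)nn1`, gives 726 nM in this assay.

Among the measured compounds shown here, compound 2 stands level with compound 1 on the two numbers at hand: the single step measured so far, a 1.1-fold lower number from compound 1 to compound 2 (0.06 log units; within the scatter), swaps a butyl chain for a 1-hydroxy-1-methylethyl group without moving the read-out beyond the scatter. Compound 3, `CC(C)CC(C)(O)c1cn(CCNc2nonc2/C(=N/O)Nc2ccc(F)c(Br)c2)nn1`, takes compound 2 a step further: isopropyl in place of hydrogen on a saturated chain carbon, two bonds along the chain from an aromatic carbon and an oxygen on a saturated carbon. For the measured compounds named here, only that one measured step bears on this change, and it shows that rebuilding the group on the aromatic carbon, whether as a plain chain or as a branched hydroxylated unit, left the number essentially where it was. Going by the values given here, with no step of real size to lean on, compound 3 is expected to remain close to compound 2, with an expected step of a 1.0-fold lower number from compound 2 to compound 3 (0.02 log units; within the scatter) that should not exceed the scatter. The estimate for compound 3 in this assay is 700 nM, ranging from 300 nM to 1600 nM.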

Compound 3, half-maximal inhibitory concentration: 689 nM
Beside the measured number, compound 3's estimate is 1.0-fold (0.01 log units) above it; low and high end bracket the measured number.
By their numbers in this assay, from the lowest: compounds 3, 2 and 1 (each within the scatter of the next).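

In this assay, adding isopropyl to the saturated chain carbon, which turns 1-hydroxy-1-methylethyl into 1-hydroxy-1,3-dimethylbutyl, gives a 1.1-fold lower number from compound 2 to compound 3 (0.02 log units; within the scatter), so this position accepts the three extra carbons without the number leaving the scatter. Against the plain butyl chain, the larger hydroxylated group gives a 1.2-fold lower number from compound 1 to compound 3 (0.08 log units; within the scatter), which places all three groups on the aromatic carbon level with one another in this assay. Nothing at hand explains why the number stays level across these groups.

Going by these compounds, it remains open whether this level read-out would hold for a phenyl ring, an amine or a carboxylic acid at the same chain position. On these data alone, it is equally open whether a longer chain there would finally move the number beyond the scatter.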